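A few compounds are considered here, and "the series" means these few. Any claim that something is new, unique, unknown or untested is made for them only; others in the source may bear on it.

Measured so far:
compound 1, `O=S(=O)(/C=C/c1cccnc1Cl)c1ccccc1F`: 217 nM
compound 2, `O=S(=O)(/C=C\c1cccnc1Cl)c1ccccc1F`: 3390 nM

Of these two values in an assay on U2OS cells for activation of nuclear factor erythroid 2-related factor 2 (Homo sapiens), read by beta-arrestin recruitment, with a stated time of 6 h (a lower number here means that less compound is needed, a higher number that more compound is needed for the effect), compound 2 has the higher number. Within the data shown here, the one comparison available is a 16-fold higher number from compound 1 to compound 2 (1.19 log units; beyond the scatter), a step that rests on (the fact that compounds 1 and 2 differ only in the configuration as drawn). Compound 3, `O=S(=O)(/C=C\c1cccnc1Cl)c1ccccc1Cl`, has not yet been measured. It differs from compound 2 by chloro in place of fluoro on an aromatic carbon, so a chloro enters where a fluoro leaves, on the same six-membered aromatic ring of carbon only. Among the measured compounds shown here, no measured step involves this exchange: the single step measured concerns the drawn configuration of the double bond, and compound 3 keeps the configuration of compound 2. With nothing pointing in either direction, the expected step of a 1.0-fold higher number from compound 2 to compound 3 (0.00 log units; within the scatter) is one that stays within the usual scatter. Compound 3 is therefore estimated to give 3400 nM in this assay, with a range from 1100 nM to 10000 nM.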

Compound 3, half-maximal effective concentration: 384 nM
Compound 3: the middle estimate sits 8.9-fold (0.95 log units) above what was measured; the measured number lies below the stated range.
By their numbers in this assay, from the lowest: compounds 1 and 3 (each within the scatter of the next); then compound 2.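

In this assay the exchange of fluoro for chloro on an aromatic carbon ortho to a large group gives an 8.8-fold lower number from compound 2 to compound 3 (0.95 log units; beyond the scatter) and so shows that this position responds to a change of a single halogen atom. Until now, only the drawn configuration of the double bond had been seen to move the number, whereas here that double bond is drawn Z in both compounds and the change lies on the aromatic ring. The information available does not bear on why this exchange moves the number.

On these data alone, whether the same exchange would have a similar effect with the double bond drawn E remains open. Also open, as far as these compounds go, is how other groups at this place, such as bromo, methyl, an amine or a carboxylic acid, would compare with fluoro and chloro.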